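Compound 3 to compound 4: trifluoromethyl in place of fluoro

The compounds below may be only part of what the source reports. "The series", "measured", "known", "first", "only" and "open" are said of these compounds alone.

Among the measured compounds shown here, in a functional assay on A549 cells (Homo sapiens) for cytotoxicity, read by MTT assay, with a stated time of 48 h (a higher number here means a weaker inhibitor, a lower number a stronger inhibitor), compound 3 `O=C(O)CN1C(=O)/C(=C/c2nc3ccccc3n2Cc2ccc(F)cc2)SC1=S` gives 3570 nM, the lowest of three numbers so far. Compound 1 `O=C(O)CN1C(=O)/C(=C/c2nc3ccccc3n2Cc2ccc(Br)cc2F)SC1=S` gives 27300 nM, and compound 2 `N#Cc1ccc(Cn2c(/C=C3\SC(=S)N(CC(=O)O)C3=O)nc3ccccc32)cc1` gives 26600 nM.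

Compound 4 `O=C(O)CN1C(=O)/C(=C/c2nc3ccccc3n2Cc2ccc(C(F)(F)F)cc2)SC1=S` carries trifluoromethyl in place of fluoro on an aromatic carbon, para to a large group: trifluoromethyl in place of fluoro on an aromatic carbon.

For the measured compounds named here, the nearest precedent is a 7.5-fold lower number from compound 2 to compound 3 (0.87 log units; beyond the scatter), where a nitrile gives way to fluoro at that aromatic carbon. The step of a 7.6-fold lower number from compound 1 to compound 3 (0.88 log units; beyond the scatter) is of similar size. Both are modest and beyond the scatter, and both end at fluoro. A rise in this assay is therefore expected, probably smaller than these steps, with a 2.5-fold higher number from compound 3 to compound 4 (0.40 log units; beyond the scatter) as the expected step. Compound 4 is estimated at 9000 nM, with an expected range of 3000 nM to 28000 nM.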

Compound 4, half-maximal inhibitory concentration: 25300 nM
Beside the measured number, compound 4's estimate is 2.8-fold (0.45 log units) below it; the measured number falls inside the stated range.
By their numbers in this assay, from the lowest: compound 3; then compounds 4, 2 and 1 (each within the scatter of the next).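

Trifluoromethyl does not hold the low number seen with fluoro at this aromatic carbon in this assay (a 7.1-fold higher number from compound 3 to compound 4 (0.85 log units; beyond the scatter)). Compound 4 instead sits level with the nitrile and 4-bromo-2-fluorophenyl compounds (a 1.1-fold lower number from compound 2 to compound 4 (0.02 log units; within the scatter); a 1.1-fold lower number from compound 1 to compound 4 (0.03 log units; within the scatter)), leaving compound 3 alone among these four at the low end. Nothing measured here explains why this single change matters so much.

Going by these compounds, how chloro, methyl or an amine would read at this aromatic carbon remains open. So does whether any group other than fluoro can reach the number of compound 3.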